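The source may report more compounds than this note shows. Statements on the series, on what has been measured and on what is new or still open speak of the compounds shown alone.

Compound 1 `C#CCSc1nc(Sc2nccs2)c(C#N)c(-c2ccc(Br)cc2)n1` gives 12100 nM
Compound 2 `C#CCSc1nc(Sc2nncs2)c(C#N)c(-c2cc(OC)c(OC)c(OC)c2)n1` gives 7960 nM
Compound 3 `C#CCSc1nc(Sc2nnnn2CCN(C)C)c(C#N)c(-c2cccc(Cl)c2)n1` gives 6480 nM

Within the data shown here, these values come from a functional assay on PC-9 cells (Homo sapiens) for antiproliferative activity, read by MTT assay (on this read-out lower numbers stand for stronger inhibition and higher numbers for weaker inhibition), and no two of the compounds differ in one place only, so no single structural step can be read from them. Compound 2 (7960 nM) lies within the scatter of both compound 3 (6480 nM) and compound 1 (12100 nM), and compound 3 is its nearest neighbour on the numbers.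

Compound 4 `C#CCSc1nc(Sc2nc(C)cs2)c(C#N)c(-c2cc(OC)c(OC)c(OC)c2)n1` has not yet been measured in this assay. It keeps all of compound 2 except the group on a sulfur whose other neighbour is an aromatic carbon, where 4-methyl-1,3-thiazol-2-yl stands in place of 1,3,4-thiadiazol-2-yl (4-methyl-1,3-thiazol-2-yl in place of 1,3,4-thiadiazol-2-yl on a sulfur).

Among the measured compounds shown here, the data hold no measured pair that isolates this change, so its direction cannot be fixed with any confidence. For the measured compounds named here, compound 2 (7960 nM) stays within the scatter of the other two compounds even though they differ from it in this group and elsewhere, and that closeness is the only guide available. No step beyond the scatter is therefore expected. The estimated change is small (a 1.2-fold lower number from compound 2 to compound 4 (0.09 log units; within the scatter)). Compound 4 is expected at 6500 nM (estimated range 2200 nM to 19000 nM).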

Compound 4, half-maximal inhibitory concentration: > 20000 nM
Compound 4 ended at the assay's limit; the forecaster's own chance of this, stated with the estimate: 10%; middle value at least 3.0-fold (0.48 log units) from the limit.
By their numbers in this assay, from the lowest: compounds 3, 2 and 1 (each within the scatter of the next). At a limit, above all of these: compound 4.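

In this assay, among these compounds, replacing 1,3,4-thiadiazol-2-yl with 4-methyl-1,3-thiazol-2-yl on a sulfur whose other neighbour is an aromatic carbon gives an at least 2.5-fold higher number from compound 2 to compound 4 (0.40 log units; beyond the scatter), the first single-place change that can be read in this set. The earlier compounds shown here differ from one another in more than one place, so they could not show that this group alone moves the read-out; this pair shows that it does, with the rest of compound 2 unchanged. Compound 4 reads > 20000 nM, which is a limit of the assay and not a number, so the step has no upper end that can be stated: the limit of > 20000 nM in this assay, at which 1 of the 4 values shown sits.

The change swaps the ring and adds a methyl in one move, so the pair cannot separate the two, and a plain 1,3-thiazol-2-yl on the same sulfur would be needed to tell them apart. The compounds shown also leave open how this sulfur would tolerate a simple primary amine chain or a carboxylic acid in place of these rings, with the rest of compound 2 kept.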